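Cytotoxicity notes on the step to compound 4

The source may report more compounds than this note shows. Statements on the series, on what has been measured and on what is new or still open speak of the compounds shown alone.

Measured in a toxicity assay on HepG2 2.2.15 cells (Homo sapiens) for cytotoxicity, read by CellTiter-Glo; on this read-out lower numbers stand for higher toxicity in this test and higher numbers for lower toxicity in this test:
- compound 1 `N#CC1CC(=O)N(c2cnn3c2CN(C(=O)Nc2cc(F)c(F)c(F)c2)C(C2CC2)C3)C1`: > 200000 nM
- compound 2 `O=C1CC(c2ncc(F)cn2)CN1c1cnn2c1CN(C(=O)Nc1cc(F)c(F)c(F)c1)C(C1CC1)C2`: 115000 nM
- compound 3 `O=C1c2ccccc2CN1c1cnn2c1CN(C(=O)Nc1cc(F)c(F)c(F)c1)C(C1CC1)C2`: 38500 nM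

The entry for compound 1, > 200000 nM, is a limit of the assay and not a number. Compound 3 stands lowest of the measured numbers at 38500 nM, and compound 2 lies higher at 115000 nM.

Compound 4 `O=C1CC(c2nccs2)CN1c1cnn2c1CN(C(=O)Nc1cc(F)c(F)c(F)c1)C(C1CC1)C2` carries 2-oxo-4-(1,3-thiazol-2-yl)pyrrolidin-1-yl on the aromatic carbon that holds the varied group in compound 3: a group of 11 heavy atoms (7 carbon, 2 nitrogen, 1 oxygen, 1 sulfur; one five-membered non-aromatic ring with 1 hetero atom, one five-membered aromatic ring with 2 hetero atoms) in place of a group of 10 heavy atoms (8 carbon, 1 nitrogen, 1 oxygen; one five-membered non-aromatic ring with 1 hetero atom, one six-membered aromatic ring of carbon only), on an aromatic carbon.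

Within the data shown here, two measured steps bear on this change. The first is an at least 5.1-fold lower number from compound 1 to compound 3 (0.71 log units; beyond the scatter), which reaches the group that compound 4 gives up. The second is an at least 1.7-fold lower number from compound 1 to compound 2 (0.24 log units; that floor lies within the scatter), which places an aromatic ring on a saturated ring carbon, as compound 4 also has. Compound 2 at 115000 nM is therefore the closer guide.

A modest move to a higher number in this assay is expected, with the estimated step being a 2.2-fold higher number from compound 3 to compound 4 (0.34 log units; beyond the scatter). For compound 4 the estimate is 85000 nM, with an expected range of 35000 nM to 190000 nM.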

Compound 4, half-maximal cytotoxic concentration: 115000 nM
Compound 4: middle estimate off by 1.4-fold (0.13 log units), on the low side, within the range that was stated.
By their numbers in this assay, from the lowest: compound 3; then compounds 2 and 4 (each within the scatter of the next). At a limit, above all of these: compound 1.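

In this assay, 2-oxo-4-(1,3-thiazol-2-yl)pyrrolidin-1-yl on the aromatic carbon gives a 3.0-fold higher number from compound 3 to compound 4 (0.48 log units; beyond the scatter), so the group of compound 3 is not matched in its reading by this lactam carrying an aromatic ring on a saturated ring carbon. Exchanging the aromatic ring on that carbon gives no change at the digits printed from compound 2 to compound 4 (within the scatter), and 1,3-thiazol-2-yl and 5-fluoropyrimidin-2-yl are not told apart in this read-out. The comparison with cyano, an at least 1.7-fold lower number from compound 1 to compound 4 (0.24 log units; that floor lies within the scatter), gives only a floor, because the entry for compound 1 is a limit of the assay and not a number: the limit of > 200000 nM in this assay, at which 1 of the 4 values shown sits.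

From the compounds shown here alone, it remains open whether an amine or a carboxylic acid on the saturated ring carbon would read like the two aromatic rings. The shared core stays constant, so these steps say nothing about any other core.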